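Oxime Propylation in a Pyridinylpiperazine Series

The compounds below may be only part of what the source reports. "The series", "measured", "known", "first", "only" and "open" are said of these compounds alone.

Compound 1 `O/N=C(\CCN1CCN(c2ccccn2)CC1)c1ccccc1` gives 4.4 nM in a functional assay on HEK293 cells with D(4) dopamine receptor (Homo sapiens) as the target, read by FLIPR (on this read-out higher numbers stand for an effect only at larger amounts of compound and lower numbers for an effect already at smaller amounts), the lowest of the two numbers recorded. Going by the values given here, its only neighbour, compound 2 `O/N=C(\CCN1CCN(c2ccccn2)CC1)c1cc(F)cc(F)c1`, gives 19.4 nM in this assay; the step of a 4.4-fold higher number from compound 1 to compound 2 (0.64 log units; beyond the scatter) comes from a 3,5-difluorophenyl in place of phenyl. Compound 3 `CCCO/N=C(\CCN1CCN(c2ccccn2)CC1)c1ccccc1` differs from compound 1 at another place: propyl in place of hydrogen on an oxygen, that is, hydroxy to propoxy. Among the compounds with values here, no measured step touches this oxygen, so the difluoro step bears on it only as a reminder that changes on the periphery of this core have shifted the number modestly rather than drastically in this assay. Compound 3 is therefore expected to stay near compound 1, with a small loss allowed for, a step of a 2.3-fold higher number from compound 1 to compound 3 (0.36 log units; beyond the scatter) in this assay. The estimate for compound 3 in this assay is 10 nM, with a range from 2 nM to 60 nM.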

Compound 3, half-maximal effective concentration: 320 nM
Compound 3: middle estimate off by 32-fold (1.51 log units), on the low side, and the stated range ends below it.
By their numbers in this assay, from the lowest: compound 1; then compound 2; then compound 3.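

On this core, the oxygen bearing the hydrogen proves a far more sensitive place than the aryl ring: in this assay the change from hydroxy to propoxy gives a 73-fold higher number from compound 1 to compound 3 (1.86 log units; beyond the scatter), whereas the 3,5-difluorophenyl change gave only a 4.4-fold higher number from compound 1 to compound 2 (0.64 log units; beyond the scatter). Peripheral changes on this core therefore do not all shift the number modestly, and propyl on this oxygen is not tolerated as well as the first two compounds might have suggested. Nothing available explains the size of this step.

The compounds shown leave open whether methyl or ethyl on the same oxygen would stay nearer compound 1 or compound 3, and whether a longer chain, or one ending in an amine or a carboxylic acid, would behave like propyl. They also leave open whether propoxy would produce a similar step alongside 3,5-difluorophenyl.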